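The source may report more compounds than this note shows. Statements on the series, on what has been measured and on what is new or still open speak of the compounds shown alone.

Compound 2 `C[C@@H](Cn1ccc(-c2ccc(C#N)c(Cl)c2)n1)Nc1ncccn1` carries a pyrimidin-2-yl group on its amine nitrogen. In an ADME assay on PC-3 cells (Homo sapiens) for cytotoxicity, read by CCK-8 assay, with a stated time of 6 days (a lower number here means a stronger inhibitor, a higher number a weaker inhibitor), compound 2 gives > 30000 nM, which is a limit of the assay rather than a number. Its companion compound 1 `C[C@@H](Cn1ccc(-c2ccc(C#N)c(Cl)c2)n1)NC(=O)c1ccccc1` carries a benzoyl group on the same nitrogen. In this assay compound 1 gives > 30000 nM, again a limit of the assay and not a number. The step that the two limits leave unreadable from compound 1 to compound 2 therefore cannot be read in size or direction, and the limit of > 30000 nM in this assay, at which 2 of the 2 values shown sit, is all that the two values show. Compound 3 `C[C@@H](Cn1ccc(-c2ccc(C#N)c(Cl)c2)n1)Nc1nccc(Cl)n1` differs from compound 2 by chloro in place of hydrogen on an aromatic carbon. Among the measured compounds shown here, no measured step bears directly on this change: the only step in hand, benzoyl to pyrimidin-2-yl, is unreadable, and both values sit at the same limit. With nothing pointing in either direction, the step of a number no higher from compound 2 to compound 3 (the limit leaves the size open) is expected to be of no readable size. Compound 3 is expected most likely to give a limit once more in this assay. The estimate for compound 3 is 30000 nM, in the range 8000 nM to 100000 nM.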

Compound 3, half-maximal inhibitory concentration: > 30000 nM
Compound 3: only a limit was reported; the forecaster's own chance of this, stated with the estimate: 70%; the middle value sits exactly at the limit.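

In this assay compound 3 gives > 30000 nM, a limit of the assay and not a number. The steps linking compound 3 to compound 2 and to compound 1 therefore cannot be read, and what remains is this: the limit of > 30000 nM in this assay, at which 3 of the 3 values shown sit. The compounds shown leave open whether chloro or any group on this amine nitrogen changes the read-out at all.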